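The source may hold more compounds than are shown below. What is called first, only, known or untested is meant among the compounds shown, and "the series" means these compounds.

Compound 1 `CCC(=O)NCc1cncc(N2C(=O)c3ccc(Cl)cc3C2(C)C)c1` carries a (propanoylamino)methyl group on the shared core. In an assay on cells for inhibition of cytochrome P450 11B2, mitochondrial (Homo sapiens), read by HTRF (on this read-out higher numbers stand for weaker inhibition and lower numbers for stronger inhibition), compound 1 gives 282 nM. Among the three compounds measured, compound 1 has the highest number, so the weakest inhibition, of the set. Going by the values given here, compound 3 `Cc1cccnc1C(=O)NCc1cncc(N2C(=O)c3ccc(Cl)cc3C2(C)C)c1` keeps the same core and gives 9 nM in this assay; the single change is a 31-fold lower number from compound 1 to compound 3 (1.50 log units; beyond the scatter). Among the compounds with values here, compound 2 `CCC(=O)N[C@@H]1CCCc2c1cncc2N1C(=O)c2ccc(Cl)cc2[C@@H]1C` is a more rigid relative and gives 6 nM in this assay; no single-point step connects it to compound 1, so the two values simply stand side by side.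

Compound 4 `CC(=O)N1CCN(c2cncc(N3C(=O)c4ccc(Cl)cc4C3(C)C)c2)CC1` has not yet been measured. It differs from compound 1 by 4-acetylpiperazin-1-yl in place of (propanoylamino)methyl on an aromatic carbon. Within the data shown here, the one measured step touching this region, the one to compound 3, changed only the group on the carbonyl carbon and kept the open chain and the amide hydrogen intact; compound 4 instead folds the side group into a ring and loses the amide hydrogen. Among the measured compounds shown here, no measured step therefore reveals how large this change will be, or in which direction. Compound 4 is expected to give roughly 400 nM in this assay, with a likely range from 100 nM to 2000 nM. That amounts to an expected 1.4-fold higher number from compound 1 to compound 4 (0.15 log units; within the scatter), not clearly beyond the scatter.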

Compound 4, half-maximal inhibitory concentration: 9 nM
For compound 4 the middle estimate is 44-fold (1.65 log units) above the measured one, and the stated range ends above it.
By their numbers in this assay, from the lowest: compounds 2, 3 and 4 (each within the scatter of the next); then compound 1.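

In this assay, the step from the open chain to the 4-acetylpiperazin-1-yl group gives a 31-fold lower number from compound 1 to compound 4 (1.50 log units; beyond the scatter), so this place on the aromatic ring accepts a six-membered non-aromatic ring, and the side group does not need a hydrogen-bond donor for a low number. The earlier step at this place kept both the open chain and the amide hydrogen, whereas compound 3 at 9 nM and compound 4 at 9 nM lie within the scatter of each other, which shows that two differently built side groups can both reach this range. No measurement at hand explains why the number falls with this change.

The change alters several things at once (the ring, the size of the group, the amide hydrogen and the acyl part), and the values shown cannot separate their contributions. Going by these compounds, it remains open how a piperazine with a free amine, a morpholine ring or a longer acyl chain on the piperazine would read out, and whether the 4-acetylpiperazin-1-yl group would give a similar number on the more rigid frame of compound 2.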